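The compounds below may be only part of what the source reports. "The series", "measured", "known", "first", "only" and "open" are said of these compounds alone.

Working notes on the series: in a functional assay on HepG2 cells (Homo sapiens) for inhibition, read by MTT assay, with a stated time of 24 h (on this read-out higher numbers stand for weaker inhibition of growth and lower numbers for stronger inhibition of growth), compound 1 `COc1ccc2c(c1)c(-c1nc3ccccc3n1C(=O)c1ccccc1)cn2C` gives 37900 nM and compound 2 `COc1ccc2c(c1)c(-c1nc3ccccc3n1C(=O)c1ccccc1OC)cn2C` gives 23600 nM. For the measured compounds named here, these are the only two numbers so far, and they lie within the scatter of each other, so compound 2 has no real separation from compound 1. Compound 3 `COc1ccc(C(=O)n2c(-c3cn(C)c4ccc(OC)cc34)nc3ccccc32)cc1` has not been measured. It has the same atoms as compound 2, joined differently: 4-methoxyphenyl in place of 2-methoxyphenyl on a carbonyl carbon. Going by the values given here, the only measured step that bears on this change is a 1.6-fold lower number from compound 1 to compound 2 (0.21 log units; within the scatter), with methoxy in place of hydrogen on an aromatic carbon. Among the compounds with values here, no measured pair compares 4-methoxyphenyl with 2-methoxyphenyl, so no step beyond the scatter is expected in this assay, and no direction is favoured. The estimated step is a 1.1-fold higher number from compound 2 to compound 3 (0.06 log units; within the scatter). The expected value for compound 3 is 27000 nM, with an estimated range of 11000 nM to 65000 nM.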

Compound 3, concentration for 50% growth inhibition: 12800 nM
Beside the measured number, compound 3's estimate is 2.1-fold (0.32 log units) above it; the measured number falls inside the stated range.
By their numbers in this assay, from the lowest: compounds 3, 2 and 1 (each within the scatter of the next, the first and the last beyond it).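

Methoxy in place of hydrogen on an aromatic carbon now gives a step beyond the scatter in this assay, a 3.0-fold lower number from compound 1 to compound 3 (0.47 log units; beyond the scatter) as a modest change, whereas the step from compound 1 to compound 2 stayed within it. On the carbonyl carbon, 4-methoxyphenyl in place of 2-methoxyphenyl gives a 1.8-fold lower number from compound 2 to compound 3 (0.27 log units; within the scatter) and stays within the scatter, so the two isomers are not separated in this series. No measurement on hand accounts for either step.

Whether a step beyond the scatter is specific to methoxy stays open, as the compounds shown carry no other substituent on this phenyl ring, such as an amine, a carboxylic acid or a chlorine. All three compounds also share the same core, so the effect of the same changes on any other core cannot be read.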